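The source may report more compounds than this note shows. Statements on the series, on what has been measured and on what is new or still open speak of the compounds shown alone.

Measured compounds in a functional assay on MIA PaCa-2 cells (Homo sapiens) for inhibition, read by MTT assay, with a stated time of 7 days; on this read-out lower numbers stand for stronger inhibition and higher numbers for weaker inhibition:
- compound 1 `CCN(CC)S(=O)(=O)c1ccc(S(=O)(=O)N2CCC[C@@H](C(=O)N3CCC(O)CC3)C2)cc1`: 870 nM
- compound 2 `CCC(CC)S(=O)(=O)c1ccc(S(=O)(=O)N2CCC[C@@H](C(=O)N3CCC(F)(F)CC3)C2)cc1`: 13 nM
- compound 3 `CCN(CC)S(=O)(=O)c1ccc(S(=O)(=O)N2CCC[C@@H](C(=O)N3CC[C@@H](OC)C3)C2)cc1`: 3910 nM

Compound 2 gives the lowest number of the three in this assay. Compound 1 is nearest to it and compound 3 furthest, both separated from compound 2 by gaps beyond the scatter. Within the data shown here, the single step measured, a 4.5-fold higher number from compound 1 to compound 3 (0.65 log units; beyond the scatter), concerns the amide side of the shared core and leaves the sulfonyl substituent untouched, so it says nothing direct about a change at the sulfonyl sulfur.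

Compound 4 `CC(C)CS(=O)(=O)c1ccc(S(=O)(=O)N2CCC[C@@H](C(=O)N3CCC(F)(F)CC3)C2)cc1` is compound 2 with one change: isobutyl in place of pentan-3-yl on a sulfonyl sulfur. Among the measured compounds shown here, compound 2 on the one hand and compounds 1 and 3 on the other differ in more than one place, so their values cannot be read as a step at this position. For the measured compounds named here, no measured pair isolates a change of the alkyl group on the sulfonyl sulfur; the only guidance is that compound 2, which carries an alkyl group there, gives the lowest number.

Going by the values given here, with a small alkyl group exchanged for another small alkyl group and no measured step bearing on it, the step of a 1.9-fold higher number from compound 2 to compound 4 (0.28 log units; within the scatter) is expected to stay close to the scatter, if anything toward a slightly higher number. Compound 4 is therefore estimated at 25 nM in this assay, in the range 8 nM to 80 nM.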

Compound 4, half-maximal inhibitory concentration: 80 nM
Beside the measured number, compound 4's estimate is 3.2-fold (0.51 log units) below it; low and high end bracket the measured number.
By their numbers in this assay, from the lowest: compound 2; then compound 4; then compound 1; then compound 3.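

In this assay, among these compounds, the group on the sulfonyl sulfur proves to be a position that responds to change: a 6.2-fold higher number from compound 2 to compound 4 (0.79 log units; beyond the scatter) is the first step read at this place, the only earlier step being on the amide side of the shared core. Pentan-3-yl (5 heavy atoms) and isobutyl (4 heavy atoms) are both all-carbon groups with no ring, no hydrogen-bond donors or acceptors and no net charge, so a step beyond the scatter can arise here between groups that match on all those counts. No measurement at hand accounts for this step.

On these data alone, the step rests on a single pair sharing one amide group, so whether it holds with the amide groups of compound 1 or compound 3 stays open, and the group on the sulfur in those two compounds has not been compared with either alkyl group in a single-place step. Also open, as far as these compounds go, is where a cyclopentyl group, a tert-butyl group or a longer chain such as n-hexyl on the sulfonyl sulfur would fall relative to compound 2 and compound 4.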